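Chromene series: aryl triazole replaces octyl on compound 2

The source may report more compounds than this note shows. Statements on the series, on what has been measured and on what is new or still open speak of the compounds shown alone.

Measured so far:
compound 1 `CCOC(=O)C1=Cc2ccccc2OC1(OCc1cn(CC(=O)Nc2cccc(F)c2)nn1)C(F)(F)F` gives > 150000 nM in a functional assay on HeLa cells (Homo sapiens) for inhibition, read by MTT assay, with a stated time of 24 h (a lower number here means a stronger inhibitor, a higher number a weaker inhibitor), a limit of the assay.
compound 2 `CCCCCCCCn1cc(COC2(C(F)(F)F)Oc3ccccc3C=C2C(=O)OCC)nn1` gives > 150000 nM in this assay, a limit of the assay.
compound 3 `COc1ccc(-c2cc(COC3(C(F)(F)F)Oc4ccccc4C=C3C(=O)O)on2)cc1` gives > 150000 nM in this assay, a limit of the assay.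

Compound 2 stands at the limit of this assay, and every other value shown sits at that same limit (the limit of > 150000 nM in this assay, at which 3 of the 3 values shown sit). For the measured compounds named here, the one step between measured compounds that differ in one place, a step that the two limits leave unreadable from compound 1 to compound 2, is therefore unreadable: heptyl in place of (3-fluorophenyl)carbamoyl on a saturated chain carbon bound to an aromatic nitrogen gave two limits and no number. Compound 4 `CCOC(=O)C1=Cc2ccccc2OC1(OCc1cn(-c2cccc(OC)c2)nn1)C(F)(F)F` is the next member, differing from compound 2 as follows: 3-methoxyphenyl in place of octyl on an aromatic nitrogen. No measured step bears on a change on an aromatic nitrogen of the five-membered ring with three nitrogens, so nothing shown lets a direction be read in this assay. Since all three values rest at the limit (the limit of > 150000 nM in this assay, at which 3 of the 3 values shown sit), the expectation is that compound 4 will again give no number, with an estimated step that the limit leaves unreadable from compound 2 to compound 4. For compound 4 the estimated value in this assay is 200000 nM, between 40000 nM and 1000000 nM.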

Compound 4, half-maximal inhibitory concentration: > 150000 nM
Compound 4 ended at the assay's limit; the forecaster's own chance of this, stated with the estimate: 75%; the middle value is on the limit's open side.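

Compound 4 gives > 150000 nM in this assay, a limit of the assay. No step among compound 1, compound 2 and compound 4 can be read, because each value is only a limit: the limit of > 150000 nM in this assay, at which 4 of the 4 values shown sit.

Still open, from the compounds shown here alone, is whether any change to the shared core gives a measurable value in this assay.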